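Swapping the aryl group on the piperazine nitrogen

The source may report more compounds than this note shows. Statements on the series, on what has been measured and on what is new or still open speak of the compounds shown alone.

Measured so far:
compound 1 `Nc1scc(CN2CCN(c3ccc(Cl)cc3Cl)CC2)c1C(=O)c1ccc(Cl)cc1` gives -54%
compound 2 `Nc1scc(CN2CCN(c3ccc(Cl)c(C(F)(F)F)c3)CC2)c1C(=O)c1ccc(Cl)cc1` gives -47%
compound 3 `Nc1scc(CN2CCN(c3cc(F)cc(F)c3)CC2)c1C(=O)c1ccc(Cl)cc1` gives -66%

All three were tested in a functional assay on CHO cells with adenosine receptor A1 (Homo sapiens) as the target, read by cAMP accumulation and immunoassay, with a stated time of 6 min, tested at 1 uM; a higher number here means a weaker effect of the compound at the concentration tested, a lower number a stronger effect. Among them compound 3 stands lowest, that is, strongest: a number 12 percentage points lower from compound 1 to compound 3 (beyond the scatter) and a number 19 percentage points lower from compound 2 to compound 3 (beyond the scatter), both beyond the scatter, while a number 7 percentage points higher from compound 1 to compound 2 (within the scatter) lies within it. The unmeasured compound 4 `Nc1scc(CN2CCN(c3cccc(Cl)c3)CC2)c1C(=O)c1ccc(Cl)cc1` differs from compound 3 only at the same position: 3-chlorophenyl in place of 3,5-difluorophenyl on an amine nitrogen in a ring. The three measured steps at this position moved the number by modest amounts or not at all, so compound 4 is expected to stay near compound 3, perhaps drifting slightly higher, with an expected step of a number 8 percentage points higher from compound 3 to compound 4 (within the scatter). The estimate for compound 4 is therefore -58%, expected to fall between -76% and -40%.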

Compound 4, a percentage reported as activity, at one concentration (the size of the read-out at that concentration, not a potency): -59%
For compound 4 the middle estimate is 1 percentage points above the measured one, within the range that was stated.
By their numbers in this assay, from the lowest: compounds 3, 4, 1 and 2 (each within the scatter of the next, the first and the last beyond it).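

In this assay, 3-chlorophenyl on the ring nitrogen reads the same, within the scatter, as 3,5-difluorophenyl (a number 7 percentage points higher from compound 3 to compound 4 (within the scatter)) and as 2,4-dichlorophenyl (a number 5 percentage points lower from compound 1 to compound 4 (within the scatter)), so one chlorine on the phenyl ring keeps the effect of the groups with two halogens. Only 4-chloro-3-(trifluoromethyl)phenyl stands apart from it (a number 12 percentage points lower from compound 2 to compound 4 (beyond the scatter)), and it goes against any simple reading that the number of halogens alone sets the result. No evidence at hand explains these results.

Still open, from the compounds shown here alone, is how an unsubstituted phenyl or a methoxyphenyl would read at this position.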